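Swapping the Aryl on the Triazole Nitrogen of Compound 2

The source may hold more compounds than are shown below. What is called first, only, known or untested is meant among the compounds shown, and "the series" means these compounds.

Measured so far:
compound 1 `Cc1cc(C)cc(-n2nncc2CN2C(=O)C3(C(C#N)=C(N)Oc4c3c3nc5ccccc5nc3c3ccccc43)c3ccccc32)c1` — > 50000 nM
compound 2 `CC(=O)Nc1ccc(-n2nncc2CN2C(=O)C3(C(C#N)=C(N)Oc4c(N)cc5nc6ccccc6nc5c43)c3ccccc32)cc1` — > 50000 nM

In a functional assay on HCT-116 cells (Homo sapiens) for antiproliferative activity, read by MTT assay, with a stated time of 48 h (a higher number here means a weaker inhibitor, a lower number a stronger inhibitor), compound 1 reaches only a limit, > 50000 nM. Compound 2 likewise reaches only a limit, > 50000 nM. Compound 2 therefore stands at the limit of > 50000 nM in this assay, at which 2 of the 2 values shown sit, with no number of its own. Compound 3 `N#CC1=C(N)Oc2c(N)cc3nc4ccccc4nc3c2C12C(=O)N(Cc1cnnn1-c1c(Cl)cc(Cl)cc1Cl)c1ccccc12` differs from compound 2 by 2,4,6-trichlorophenyl in place of 4-acetamidophenyl on an aromatic nitrogen. Going by the values given here, no step between measured compounds is available, so no size or direction can be drawn from them. Compound 3 is expected to give 60000 nM, within 10000 nM to 200000 nM. The expected step, a step that the limit leaves unreadable from compound 2 to compound 3, is none beyond the scatter, most likely another limit.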

Compound 3, half-maximal inhibitory concentration: 12100 nM
Beside the measured number, compound 3's estimate is 5.0-fold (0.70 log units) above it, and the stated range covers the measured number.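

In this assay, going by these compounds alone, 2,4,6-trichlorophenyl in place of 4-acetamidophenyl on this aromatic nitrogen gives an at least 4.1-fold lower number from compound 2 to compound 3 (0.61 log units; beyond the scatter), the first sign that the group at this position affects the read-out. The true size of the step stays unknown, because compound 2 has only a limit and no number of its own: the limit of > 50000 nM in this assay, at which 2 of the 3 values shown sit.

On these data alone, what stays open is whether the change depends on the loss of the acetamide or on the arrival of the three chlorines. A plain phenyl or a 4-chlorophenyl at this position would separate the two.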